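A Second Fluorine on the Phenoxy Ring

The source may hold more compounds than are shown below. What is called first, only, known or untested is meant among the compounds shown, and "the series" means these compounds.

Compound 1 `Cc1nn(C)c(Oc2ccc(I)cc2)c1/C=N\CCCCCOc1cc2oc(=O)cc(C)c2cc1Cl` gives in a functional assay on HepG2 cells (Homo sapiens) for antiproliferative activity, read by MTT assay, with a stated time of 72 h (on this read-out higher numbers stand for weaker inhibition and lower numbers for stronger inhibition), only a limit, > 25000 nM.
Compound 2 `Cc1ccc(Oc2c(/C=N\CCCCCOc3cc4oc(=O)cc(C)c4cc3Cl)c(C)nn2C)cc1` gives in this assay a value of 10300 nM.
Compound 3 `Cc1nn(C)c(Oc2ccc(F)cc2)c1/C=N\CCCCCCOc1cc2oc(=O)cc(C)c2cc1Cl` gives in this assay a value of 12500 nM.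

Among the two numbers that are not limits, compound 3 stands highest, with compound 2 the nearest, and the gap between them lies within the scatter. The limit of compound 1 is stated in the limit of > 25000 nM in this assay, at which 1 of the 3 values shown sits.

Compound 4 `Cc1nn(C)c(Oc2ccc(F)c(F)c2)c1/C=N\CCCCCCOc1cc2oc(=O)cc(C)c2cc1Cl` differs from compound 3 in one place: fluoro in place of hydrogen on an aromatic carbon. Within the data shown here, the single measured step, an at least 2.4-fold lower number from compound 1 to compound 2 (0.38 log units; beyond the scatter), concerns a methyl in place of iodo on an aromatic carbon, so it does not bear on adding a fluoro next to an existing one. Among the measured compounds shown here, with no step in the data speaking to this change, the expectation is a step of no change at the digits printed from compound 3 to compound 4 (within the scatter), that is, none beyond the scatter. Compound 4 is therefore estimated at 12500 nM in this assay, within a range from 5000 nM to 30000 nM.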

Compound 4, half-maximal inhibitory concentration: > 25000 nM
Compound 4 ended at the assay's limit; the forecaster's own chance of this, stated with the estimate: 25%; middle value at least 2.0-fold (0.30 log units) away from the limit.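

In this assay compound 4 gives > 25000 nM, which is a limit of the assay and not a number. The change from 4-fluorophenoxy to 3,4-difluorophenoxy gives an at least 2.0-fold higher number from compound 3 to compound 4 (0.30 log units; that floor lies within the scatter); this is the first step shown on a carbon ortho to a fluoro group, and it points toward weaker inhibition, although its floor alone does not clear the scatter. Compound 4 now stands at the same limit as compound 1: the limit of > 25000 nM in this assay, at which 2 of the 4 values shown sit.

As far as these compounds go, how far the true number of compound 4 lies past the limit stays open. Also open, from the compounds shown here alone, is whether a chloro, a methoxy or an amine on that same carbon would behave as the second fluoro does, and whether a longer chain would alter the outcome.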